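Swapping Benzyl for Cyclopropylmethyl on a Shared Core

This account rests on a few compounds, and the source may have more. Where it says the series, first, only, none or still open, it means among the compounds named here.

Compound 1 `O=C(O)CCn1c(=O)oc2cc(OCc3ccccc3)c(Cl)cc21` carries a benzyloxy group on its aromatic ring, and in a physicochemical assay for lipophilicity, read by HPLC, at pH 7.4 (on this read-out higher numbers stand for higher lipophilicity and lower numbers for lower lipophilicity), compound 1 gives 2.71. Two related compounds help place that number. Compound 3 `C[C@@H](Oc1cc2oc(=O)n(CCC(=O)O)c2cc1Cl)c1ccc(Cl)cn1` gives 2.65 in this assay, a number that does not differ from compound 1 beyond the usual scatter. Compound 2 `C[C@@H](Oc1cc2c(cc1Cl)N(CCC(=O)O)C(=O)CO2)c1ccccn1` gives 1.56, clearly lower than compound 1. Compound 1 thus stands at the upper end of the three numbers shown.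

Compound 4 `O=C(O)CCn1c(=O)oc2cc(OCC3CC3)c(Cl)cc21` has not yet been measured. Among the compounds with values here, it differs from compound 1 in one place: cyclopropyl in place of phenyl on a saturated chain carbon bound to an oxygen on an aromatic ring No measured pair among the three compounds shows this same change, so the expectation rests on the change itself, in which a six-carbon aromatic ring leaves and a three-carbon ring enters. A step of moderate size downward, beyond the scatter, is expected in this assay, a number 0.91 log units lower from compound 1 to compound 4 (beyond the scatter). Compound 4 is therefore estimated at about 1.8, with a likely range from 1.3 to 2.3.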

Compound 4, distribution coefficient: 2.09
Compound 4: the middle estimate sits 0.29 log units below what was measured, within the range that was stated.
By their numbers in this assay, from the lowest: compound 2; then compound 4; then compounds 3 and 1 (each within the scatter of the next).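

Within the data shown here, compound 1 and compound 4 form the first measured pair here that differs in one place, and they show that the group at this position moves the read-out of this assay: cyclopropyl in place of phenyl gives a number 0.62 log units lower from compound 1 to compound 4 (beyond the scatter). This single pair cannot separate ring size from aromatic character, as the ring that leaves is a six-membered aromatic one and the ring that enters is a three-membered non-aromatic one. Nothing available explains the size of this step.

As far as these compounds go, whether a cyclohexyl group, a non-aromatic ring the size of the phenyl that left, would fall nearer compound 1 or compound 4 stays open, as does the effect of an amine or a longer chain at this place. Also open, from the compounds shown here alone, is whether the same change would give a step of similar size on the core of compound 2.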